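Methoxy in place of carboxy, close to the assay limit

The source may hold more compounds than are shown below. What is called first, only, known or untested is meant among the compounds shown, and "the series" means these compounds.

In an ADME assay on HepG2 cells (Homo sapiens) for cytotoxicity, with a stated time of 72 h (a higher number here means that more compound is needed for the effect, a lower number that less compound is needed), compound 1 (`Cc1cc(NC(=O)Nc2ccc(SC(F)(F)F)cc2)c2ccccc2n1`) gives 20000 nM as a measured number. Compound 2 (`Cc1cc(NC(=O)Nc2ccc(C(=O)O)cc2)c2ccccc2n1`) gives > 25000 nM and this is a limit of the assay, not a number. Compound 2 thus stands only at the limit of > 25000 nM in this assay, at which 1 of the 2 values shown sits, and has no exact place in the series.

Compound 3 (`COc1ccc(NC(=O)Nc2cc(C)nc3ccccc23)cc1`) carries methoxy in place of carboxy on an aromatic carbon, para to a large group (methoxy in place of carboxy on an aromatic carbon).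

Going by the values given here, one measured step bears on this change, the replacement of (trifluoromethyl)sulfanyl by carboxy on an aromatic carbon: an at least 1.2-fold higher number from compound 1 to compound 2 (0.09 log units; that floor lies within the scatter) and it is bounded on one side only. Among the compounds with values here, no measured step yet starts from methoxy. Resting on the floor of an at least 1.2-fold higher number from compound 1 to compound 2 (0.09 log units; that floor lies within the scatter) no step beyond the scatter is expected in this assay and no direction is favoured. The expected step is an at least 1.2-fold lower number from compound 2 to compound 3 (0.09 log units; that floor lies within the scatter) and a further limit in place of a number would be no surprise. The estimated value for compound 3 is 20000 nM within an expected range of 9000 nM to 30000 nM for this measurement.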

Compound 3, half-maximal effective concentration: > 25000 nM
Compound 3: only a limit was reported (the forecaster's own chance of this, stated with the estimate: 45%); middle value at least 1.2-fold (0.09 log units) away from the limit.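

In this assay compound 3 gives > 25000 nM, which is a limit of the assay and not a number. Exchanging (trifluoromethyl)sulfanyl for methoxy, para to a large group, gives an at least 1.2-fold higher number from compound 1 to compound 3 (0.09 log units; that floor lies within the scatter), so this change shows no step beyond the scatter, while the step between the two limits, from carboxy to methoxy, cannot be read. With compound 3 joining compound 2, methoxy and carboxy now both leave the series at the same assay limit, and the readings for this position gather there: the limit of > 25000 nM in this assay, at which 2 of the 3 values shown sit.

Going by these compounds alone, compound 1 remains the only compound with a measured number, 20000 nM, and the floors of its steps lie within the scatter, so it is still open whether any change at this position moves the number clearly in either direction. From the compounds shown here alone, it is also open how far compound 2 and compound 3 lie past their limits, and whether an amine, a nitrile or a longer chain on this aromatic carbon would give a measured number well inside the range of the assay.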